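Small ester change on a compound without a clear neighbour

The compounds below may be only part of what the source reports. "The series", "measured", "known", "first", "only" and "open" are said of these compounds alone.

compound 1 `COC(=O)NC(=O)c1ccsc1NC(=O)c1ccc(S(=O)(=O)N2CCC(C)CC2)cc1`: 9.13 ug/mL
compound 2 `COC(=O)NC(=O)c1ccsc1NC(=O)c1ccc(S(=O)(=O)N2CCC(OC)CC2)cc1`: 18 ug/mL
compound 3 `COC(=O)NC(=O)c1ccsc1NC(=O)c1ccc(S(=O)(=O)N2CCC(c3ccccc3)CC2)cc1`: "nd" (no result reported)
compound 4 `CCOC(=O)NC(=O)c1ccsc1NC(=O)c1ccc(S(=O)(=O)N2CCC(OC)CC2)cc1`: not yet measured

In a toxicity assay on Vero cells (Chlorocebus sabaeus) for cytotoxicity, read by MTT assay (on this read-out lower numbers stand for stronger inhibition and higher numbers for weaker inhibition), compound 2 gives 18 ug/mL, within the usual scatter of compound 1 at 9.13 ug/mL. No number was reported for compound 3. The move to compound 4 is methyl in place of hydrogen on a saturated chain carbon bound to an oxygen next to a carbonyl group: methoxycarbonyl becomes ethoxycarbonyl. Among the measured compounds shown here, the only measured step is a 2.0-fold higher number from compound 1 to compound 2 (0.29 log units; within the scatter). It is a different change elsewhere in the molecule, methoxy in place of methyl on a saturated ring carbon. For the measured compounds named here, no measured pair tests the ester end, so this is weak guidance, and no shift beyond the scatter is expected. The expected step is a 1.2-fold lower number from compound 2 to compound 4 (0.08 log units; within the scatter). For compound 4 the estimated value is 15 ug/mL, with an expected range from 7 ug/mL to 32 ug/mL.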

Compound 4, half-maximal inhibitory concentration: 21 ug/mL
Estimate against measurement, compound 4: 1.4-fold (0.15 log units) below, within the range that was stated.
By their numbers in this assay, from the lowest: compounds 1, 2 and 4 (each within the scatter of the next, the first and the last beyond it).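

Going from methoxycarbonyl to ethoxycarbonyl gives a 1.2-fold higher number from compound 2 to compound 4 (0.07 log units; within the scatter) in this assay. Among the compounds shown here, this is the first pair that tests this end of the molecule, and it shows that one added methyl on this chain carbon leaves the cytotoxicity reading within the scatter. Nothing measured here explains this result.

From the compounds shown here alone, whether a longer chain such as butoxycarbonyl, or a benzyloxycarbonyl group, would also stay within the scatter remains open. So does whether ethoxycarbonyl would behave the same way on the core of compound 1.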